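A few compounds are considered here, and "the series" means these few. Any claim that something is new, unique, unknown or untested is made for them only; others in the source may bear on it.

Compound 1: `COc1ccc(-c2coc3cc(OCCCSC(=S)N4CCN(Cc5ccccc5)CC4)ccc3c2=O)cc1` — 14900 nM
Compound 2: `COc1ccc(-c2coc3cc(OCCCCSC(=S)N4CCN(C(=O)OC(C)(C)C)CC4)ccc3c2=O)cc1` — 4610 nM

Both compounds were tested in a functional assay on PC-3 cells (Homo sapiens) for inhibition, read by MTT assay, with a stated time of 48 h; on this read-out higher numbers stand for weaker inhibition and lower numbers for stronger inhibition. Compound 1 gives 14900 nM, the highest of the two numbers. Compound 2 gives the lower number, 4610 nM, and that gap lies beyond the usual scatter. Compound 3 is `COc1ccc(-c2coc3cc(OCCCSC(=S)N4CCN(C(=O)OC(C)(C)C)CC4)ccc3c2=O)cc1`. It differs from compound 1 in one place: tert-butoxycarbonyl in place of benzyl on an amine nitrogen in a ring. Compound 2 carries the same entering group on a longer chain and shows a lower number, so the change in compound 3 is expected to move in that direction. The expected step is a 2.5-fold lower number from compound 1 to compound 3 (0.40 log units; beyond the scatter), toward a lower number, beyond the scatter. Compound 3 is estimated at 6000 nM, with a range from 2500 nM to 15000 nM.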

Compound 3, half-maximal inhibitory concentration: 1970 nM
Compound 3: middle estimate off by 3.0-fold (0.48 log units), on the high side; measured number outside the range, below it.
By their numbers in this assay, from the lowest: compound 3; then compound 2; then compound 1.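

In this assay, putting tert-butoxycarbonyl in place of benzyl on the ring amine nitrogen, with the chain and the rest of the molecule unchanged, gives a 7.6-fold lower number from compound 1 to compound 3 (0.88 log units; beyond the scatter). Within the data shown here, this is the first direct reading of this change, as compound 1 and compound 2 differ in more than one place. Nothing shown explains why the number falls.

On these data alone, it remains open whether the step follows the loss of the aromatic ring or the arrival of the carbonyl. A free amine, an acetyl or a cyclohexylmethyl group on the same nitrogen could help separate these.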